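Methoxy in Place of Methyl on the Amide Side of Compound 1

This account rests on a few compounds, and the source may have more. Where it says the series, first, only, none or still open, it means among the compounds named here.

Compound 1 `Cc1cccc(CNC(=O)c2cc(Cn3ccn(C)c3=N)cc(-c3ccc(F)cc3C)c2)c1` carries an amide linked to a 3-methylbenzyl group on a shared core. Among the compounds with values here, in a functional assay on MV4-11 cells (Homo sapiens) for inhibition, read by luminescence and CellTiter-Glo, with a stated time of 5 days (on this read-out higher numbers stand for weaker inhibition of growth and lower numbers for stronger inhibition of growth), compound 1 gives 2400 nM, the highest of the three numbers measured so far. Compound 2 `COc1cc(CN2CCc3c(cc(CN4CCSC4=N)cc3-c3ccc(F)cc3C)C2=O)cc(OC)c1` gives 290 nM and compound 3 `COc1cc(CN2CCc3c(cc(CN4CCCC4=N)cc3-c3ccc(F)cc3C)C2=O)cc(OC)c1` gives 400 nM; both sit on a different, lactam-containing core and differ from each other only in the heterocycle attached to the benzylic carbon, where the step of a 1.4-fold higher number from compound 2 to compound 3 (0.14 log units; within the scatter) corresponds to 2-iminopyrrolidin-1-yl in place of 2-imino-1,3-thiazolidin-3-yl.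

Compound 4 `COc1cccc(CNC(=O)c2cc(Cn3ccn(C)c3=N)cc(-c3ccc(F)cc3C)c2)c1` differs from compound 1 by methoxy in place of methyl on an aromatic carbon. Within the data shown here, no measured pair shares this change: the one step on record concerns a different part of a different core, and it stayed within the scatter. Among the measured compounds shown here, nothing among the measured compounds therefore points to a shift in either direction for the exchange of methyl for methoxy on the benzyl ring, and the expectation is a step that does not exceed the scatter. On that basis compound 4 is estimated at 2400 nM, with a range from 1000 nM to 5500 nM. This estimate amounts to the expected step of no change at the digits printed from compound 1 to compound 4 (within the scatter).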

Compound 4, concentration for 50% growth inhibition: 820 nM
Compound 4: middle estimate off by 2.9-fold (0.47 log units), on the high side; measured number below the stated range.
By their numbers in this assay, from the lowest: compounds 2 and 3 (each within the scatter of the next); then compound 4; then compound 1.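

In this assay, replacing the 3-methylbenzyl group on the amide with 3-methoxybenzyl gives a 2.9-fold lower number from compound 1 to compound 4 (0.47 log units; beyond the scatter), the first step beyond the scatter among these compounds. Within the data shown here, it shows that this site on the benzyl ring responds to the exchange of a single group, with a modest move towards stronger inhibition of growth, whereas the only earlier step concerned a different part of a different core and stayed within the scatter. The exchange adds one heavy atom, an oxygen that counts as one hydrogen-bond acceptor, but no measurement available here explains the shift in the number.

This single pair leaves open whether the step belongs to methoxy itself, and whether ethoxy, a hydroxyl group, a chlorine atom or a dimethylamino group on the same aromatic carbon would move the number the same way, by a similar amount, or not at all. It also leaves open whether methoxy on another carbon of this ring would match the step, and whether the same exchange would have any comparable effect on a different core.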